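A few compounds are considered here, and "the series" means these few. Any claim that something is new, unique, unknown or untested is made for them only; others in the source may bear on it.

Compound 1 `COc1ccc(CNC(=O)CSc2nc3ccc(NC(=O)c4ccc(Cl)cc4)cc3s2)cc1` holds the lowest of the two numbers given in a functional assay on MCF7 cells (Homo sapiens) for cytotoxicity, read by MTT assay, with a stated time of 48 h (on this read-out higher numbers stand for weaker inhibition and lower numbers for stronger inhibition), where compound 1 gives 19200 nM. Compound 2 `COc1ccc(CNC(=O)CSc2nc3ccc(NC(=O)c4ccccc4)cc3s2)cc1` gives 21200 nM in this assay, a change of a 1.1-fold higher number from compound 1 to compound 2 (0.04 log units; within the scatter). Compound 3 `COc1ccc(CNC(=O)CSc2nc3ccc(NC(=O)c4ccc([N+](=O)[O-])cc4)cc3s2)cc1` yields > 100000 nM in this assay, a limit rather than a number. Compound 3 thus sits at the limit of > 100000 nM in this assay, at which 1 of the 3 values shown sits. Compound 4 `O=C(CSc1nc2ccc(NC(=O)c3ccc(Cl)cc3)cc2s1)NCc1ccccc1` differs from compound 1 by hydrogen in place of methoxy on an aromatic carbon. Among the measured compounds shown here, no measured step touches that place: the steps of an at least 5.2-fold higher number from compound 1 to compound 3 (0.71 log units; beyond the scatter) and an at least 4.7-fold higher number from compound 2 to compound 3 (0.67 log units; beyond the scatter) concern the nitro group on the other aromatic ring, and the chloro-to-hydrogen step stays within the scatter. A step of about a 1.1-fold higher number from compound 1 to compound 4 (0.06 log units; within the scatter) is therefore expected, none beyond the scatter. Compound 4 is estimated at 22000 nM, between 8000 nM and 60000 nM.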

Compound 4, half-maximal inhibitory concentration: 25900 nM
Estimate against measurement, compound 4: 1.2-fold (0.07 log units) below; the measured number falls inside the stated range.
By their numbers in this assay, from the lowest: compounds 1, 2 and 4 (each within the scatter of the next). At a limit, above all of these: compound 3.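

In this assay, among the compounds shown here, the change gives the first reading at the 4-methoxybenzyl end of the molecule: hydrogen in place of methoxy leaves a 1.3-fold higher number from compound 1 to compound 4 (0.13 log units; within the scatter). For the compounds shown here, at this place, para to a large group, the methoxy group can therefore go without a shift beyond the scatter, whereas the earlier steps only covered the other aromatic ring. Nothing measured here gives a cause for this result. Still open, from the compounds shown here alone, is how an amine or a carboxylic acid at this place would read, and whether a longer chain in place of the benzyl link would hold the number.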